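Adding a Second Fluorine to the Ketone Aryl Ring

The source may hold more compounds than are shown below. What is called first, only, known or untested is meant among the compounds shown, and "the series" means these compounds.

Measured so far:
- compound 1, `COc1cccc(C(=O)c2sc3nc(-c4cccs4)ccc3c2N)c1`: in a functional assay on WI-38 VA13 cells (Homo sapiens) for cytotoxicity (a lower number here means that less compound is needed, a higher number that more compound is needed for the effect), compound 1 gives 0.03 ug/mL
- compound 2, `Nc1c(C(=O)c2ccc(F)cc2)sc2nc(-c3cccs3)ccc12`: in this assay compound 2 gives 1.8 ug/mL

Among the compounds with values here, compound 2 stands at the higher of the two numbers; its only neighbour is compound 1, and the step between them is large, a 60-fold higher number from compound 1 to compound 2 (1.78 log units; beyond the scatter). That step exchanged the whole aryl group on the carbonyl carbon, 4-fluorophenyl in place of 3-methoxyphenyl.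

Compound 3, `Nc1c(C(=O)c2ccc(F)cc2F)sc2nc(-c3cccs3)ccc12`, differs from compound 2 by a much smaller change: fluoro in place of hydrogen on an aromatic carbon. In other words, the 4-fluorophenyl becomes 2,4-difluorophenyl while everything else in the shared core stays as it is.

Within the data shown here, no measured step bears directly on this change. Among the measured compounds shown here, the one step that exists, from compound 1 to compound 2, swapped an entire substituted ring and cannot say what a single added fluoro will do. With nothing else to lean on, the expectation for compound 3 in this assay is a step that stays within the usual scatter, no change at the digits printed from compound 2 to compound 3 (within the scatter). Compound 3 is therefore estimated at 1.8 ug/mL, with a range from 0.5 ug/mL to 6 ug/mL.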

Compound 3, half-maximal effective concentration: 2.3 ug/mL
The estimate for compound 3 lay 1.3-fold (0.11 log units) below the measured number, within the range that was stated.
By their numbers in this assay, from the lowest: compound 1; then compounds 2 and 3 (each within the scatter of the next).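

In this assay, placing a fluoro on the aromatic carbon ortho to a large group, which turns 4-fluorophenyl into 2,4-difluorophenyl, gives a 1.3-fold higher number from compound 2 to compound 3 (0.11 log units; within the scatter), so this single-atom addition does not separate the two compounds at this position. The large gap to the 3-methoxyphenyl ketone remains with the second fluoro in place, at a 77-fold higher number from compound 1 to compound 3 (1.88 log units; beyond the scatter), a step of similar size to a 60-fold higher number from compound 1 to compound 2 (1.78 log units; beyond the scatter), so both fluorinated rings sit far from compound 1 by this read-out. No measured evidence accounts for either the small step or the large ones.

Still open, on these data alone, is whether a group bigger than a single fluorine, such as a methoxy group or an amine, on that same aromatic carbon would also stay within the scatter of compound 2. Also open, as far as these compounds go, is what in the 3-methoxyphenyl ring sets compound 1 apart, which an unsubstituted phenyl ring or a hydroxyl group in place of the methoxy could begin to show.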